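A Methyl Step Carried Over to a Second Core

A few compounds are considered here, and "the series" means these few. Any claim that something is new, unique, unknown or untested is made for them only; others in the source may bear on it.

Compound 1, `CC(=O)N1N=C(Nc2nc3ccc(C)cc3s2)CC1OC1=CC=C1`, gives 160 umol/kg in a functional assay on the whole organism (Hindlimb, strain albino) with Mus musculus as the target, in the maximal electroshock model, with a stated time of 0.5 h; on this read-out higher numbers stand for an effect only at larger amounts of compound and lower numbers for an effect already at smaller amounts.
Compound 2, `CC(=O)N1N=C(Nc2nc3ccccc3s2)CC1OC1=CC=C1`, gives 382 umol/kg.
Compound 3, `COc1ccc(/C=C/C(=O)Nc2nc3ccccc3s2)cc1`, gives 435 umol/kg.

Compound 1 and compound 2 share one core and differ in a single place, (methyl in place of hydrogen on an aromatic carbon). This change produced a 2.4-fold lower number from compound 2 to compound 1 (0.38 log units; beyond the scatter). Compound 3 carries another core; the difference between the two cores is not broken down here. In this assay the number of compound 3 lies within the scatter of that of compound 2, so nothing separates them.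

Compound 4, `COc1ccc(/C=C/C(=O)Nc2nc3ccc(C)cc3s2)cc1`, has not been measured. It differs from compound 3 by methyl in place of hydrogen on an aromatic carbon, which is the same change as that from compound 2 to compound 1. Because of a 2.4-fold lower number from compound 2 to compound 1 (0.38 log units; beyond the scatter), a step of similar size is expected in this assay from compound 3 to compound 4, namely a 2.2-fold lower number from compound 3 to compound 4 (0.34 log units; beyond the scatter), though this rests on a single earlier example made on a different core, so the range is kept wide. Compound 4 is therefore estimated at 200 umol/kg, expected to fall between 100 umol/kg and 420 umol/kg.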

Compound 4, dose for half-maximal effect: 209 umol/kg
For compound 4 the middle estimate is 1.0-fold (0.02 log units) below the measured one; the range from low to high includes it.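

Methyl in place of hydrogen on an aromatic carbon gave a 2.1-fold lower number from compound 3 to compound 4 (0.32 log units; beyond the scatter) in this assay, so the step seen on the core of compound 1 also appears on the core of compound 3. The two steps do not differ, and in this series the change carried from one core to the other at much the same size: the same change on two cores in this assay, a 2.4-fold lower number (0.38 log units; beyond the scatter) from compound 2 to compound 1 and a 2.1-fold lower number (0.32 log units; beyond the scatter) from compound 3 to compound 4, 1.1-fold (0.06 log units) apart, within the scatter of two such steps. Among these compounds, this rests on only two pairs in a single assay at one stated time, so it sets no general rule for other cores and does not show why the methyl has this effect.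

The compounds shown carry only hydrogen or methyl at this place, which leaves open whether an ethyl group, a chlorine atom or an amine there would give a step of like size. They also leave open whether the methyl step would hold on a third core or at another time in the same model.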